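Chloro for hydroxy on the amide aryl tail

This account rests on a few compounds, and the source may have more. Where it says the series, first, only, none or still open, it means among the compounds named here.

Three compounds share one core. Compound 1 `Cn1c(Cc2nn(C)c(=O)c3ccccc23)nnc1SCCCCCCCCCCC(=O)Oc1ccc(Cl)cc1Cl` gives 8700 nM in an assay on isolated protein (Mus musculus) for inhibition of IL15-IL15 receptor (Homo sapiens), read by resazurin assay, with stated times of 30 min and 2.5 days; a higher number here means a weaker inhibitor, a lower number a stronger inhibitor. Compound 2 `Cn1c(Cc2nn(C)c(=O)c3ccccc23)nnc1SCCCCCCCC(=O)Nc1ccc(O)cc1` reaches only a limit of the assay, > 30000 nM, in this assay. Compound 3 `COc1ccc(NC(=O)CSc2nnc(Cc3nn(C)c(=O)c4ccccc34)n2C)cc1` is reported as "not active" (no number reported) in this assay. Compound 2 therefore stands at the limit of > 30000 nM in this assay, at which 1 of the 3 values shown sits, with compound 3 the one further entry without a number. Compound 4 `Cn1c(Cc2nn(C)c(=O)c3ccccc23)nnc1SCCCCCCCC(=O)Nc1ccc(Cl)cc1` is not yet measured; it differs from compound 2 by chloro in place of hydroxy on an aromatic carbon. For the measured compounds named here, no measured pair isolates this change, so the size of the step is open. Compound 4 is expected near 20000 nM, between 5000 nM and 60000 nM, with a fair chance that only a limit is again reported. That estimate means an expected step of an at least 1.5-fold lower number from compound 2 to compound 4 (0.17 log units; that floor lies within the scatter), hardly beyond the scatter.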

Compound 4, half-maximal inhibitory concentration: 800 nM
Compound 4: middle estimate off by 25-fold (1.40 log units), on the high side; the whole stated range lies above it.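

Swapping hydroxy for chloro on this aromatic ring gives an at least 37-fold lower number from compound 2 to compound 4 (1.57 log units; beyond the scatter). For the compounds shown here, this is the first comparison here that changes only one place, and it shows that a single atom at this position can separate a compound with a measured value from one without. The true size of the step stays unknown, since the value for compound 2 is only a limit: the limit of > 30000 nM in this assay, at which 1 of the 4 values shown sits.

On these data alone, whether chloro helps or the loss of hydroxy alone matters remains open, and a plain hydrogen, fluoro or an amine here would tell these apart. As far as these compounds go, the separate roles of chain length and of the ester or amide link also remain open.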